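The source may report more compounds than this note shows. Statements on the series, on what has been measured and on what is new or still open speak of the compounds shown alone.

Compound 1 `COc1cc(-c2nnc(SCC(=O)c3ccc(C)cc3)n2N2C(=O)c3ccccc3C2=O)cc(OC)c1OC` and compound 2 `COc1cc(-c2nnc(SCc3ccccc3)n2N2C(=O)c3ccccc3C2=O)cc(OC)c1OC` share the same core and differ only in the group on a saturated chain carbon bound to a sulfur. In a functional assay on MKN-45 cells (Homo sapiens) for cytotoxicity, read by MTT assay, with a stated time of 48 h (a higher number here means a weaker inhibitor, a lower number a stronger inhibitor), compound 1 gives 9620 nM. Compound 2 gives only a limit of the assay, > 200000 nM, so it stands at the weak end of the numbers shown and no exact value for it is known. The step of an at least 20-fold higher number from compound 1 to compound 2 (1.31 log units; beyond the scatter) shows that replacing the (4-methylphenyl)carbonyl by a plain phenyl made the compound much weaker; this rests on (the limit of > 200000 nM in this assay, at which 1 of the 2 values shown sits). Compound 3 `COc1cc(-c2nnc(SCC(=O)c3ccc(F)c(F)c3)n2N2C(=O)c3ccccc3C2=O)cc(OC)c1OC` is not yet measured. It differs from compound 2 by (3,4-difluorophenyl)carbonyl in place of phenyl on a saturated chain carbon bound to a sulfur, which restores a carbonyl-bearing group like that of compound 1. Going by the values given here, the one measured step bearing on this change, from compound 1 to compound 2, was large, so compound 3 is expected to give a much lower number in this assay than compound 2 does. The estimate for compound 3 is 10000 nM (from 3000 nM to 40000 nM). This means an expected step of an at least 20-fold lower number from compound 2 to compound 3 (1.30 log units; beyond the scatter).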

Compound 3, half-maximal inhibitory concentration: > 200000 nM
Compound 3 gave a limit, no number (the forecaster's own chance of this, stated with the estimate: 15%); at least 20-fold (1.30 log units) between middle value and limit.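

With the carbonyl kept on the saturated chain carbon bound to the sulfur, changing only the ring, 3,4-difluorophenyl in place of 4-methylphenyl, gives an at least 20-fold higher number from compound 1 to compound 3 (1.31 log units; beyond the scatter) in this assay. Compound 1 and compound 2 differed in the carbonyl and the ring's methyl together, so they could not show what compound 3 now shows: the carbonyl alone does not bring a compound back from the limit, and activity at this position also depends on what the ring carries. The step between compound 2 and compound 3 cannot be read, and the comparison has a firm value on one side only: the limit of > 200000 nM in this assay, at which 2 of the 3 values shown sit.

From the compounds shown here alone, it remains open whether losing the methyl or gaining the two fluorines accounts for the loss. A plain phenylcarbonyl, or a ring carrying a single fluorine or an amine, would help separate the two.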